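The source may report more compounds than this note shows. Statements on the series, on what has been measured and on what is new or still open speak of the compounds shown alone.

Working notes on the anilino-substituted series.

Three compounds are measured. Compound 1 `COc1cccnc1Nc1cc2[nH]c(-c3cccc(C(F)(F)F)c3)nc2cn1` gives 69% in an ADME assay on microsomes from liver (Homo sapiens) for metabolic stability, read by LC-MS, with a stated time of 30 min, tested at 0.1 uM; a higher number here means that more of the compound is left, a lower number that less of the compound is left. Compound 2 `FC(F)(F)c1cccc(-c2nc3cnc(Nc4cnccn4)cc3[nH]2)c1` gives 43%, and compound 3 `FC(F)(F)c1cccc(-c2nc3cnc(Nc4cccnn4)cc3[nH]2)c1` gives 84%. Compound 3 stands highest of the three: the nearest is compound 1, the furthest compound 2, and both gaps lie beyond the scatter. The measured steps all exchange the aromatic group on the nitrogen on the aromatic ring: a number 26 percentage points lower from compound 1 to compound 2 (beyond the scatter), a number 15 percentage points higher from compound 1 to compound 3 (beyond the scatter) and a number 41 percentage points higher from compound 2 to compound 3 (beyond the scatter).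

The next compound, compound 4 `N#Cc1ccc(Nc2cc3[nH]c(-c4cccc(C(F)(F)F)c4)nc3cn2)nc1`, differs from compound 3 only there: 5-cyanopyridin-2-yl in place of pyridazin-3-yl on a nitrogen on an aromatic ring. All three measured steps bear on this change, since each swaps one six-membered aromatic group for another at the same place, and their sizes ran from modest to large. Within the data shown here, no measured compound carries a 5-cyanopyridin-2-yl group, so the direction rests on the spread of the three values alone. Compound 3 is the top of that spread, which makes a fall more likely than a rise; the expected step is a number 20 percentage points lower from compound 3 to compound 4 (beyond the scatter). For compound 4 the estimate in this assay is 64%, with a range from 44% to 84%.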

Compound 4, percent of the compound remaining: 39%
Beside the measured number, compound 4's estimate is 25 percentage points above it; measured number outside the range, below it.
By their numbers in this assay, from the lowest: compounds 4 and 2 (each within the scatter of the next); then compound 1; then compound 3.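

In this assay, the high number of the pyridazin-3-yl group does not carry over to the 5-cyanopyridin-2-yl group on this nitrogen, with a number 45 percentage points lower from compound 3 to compound 4 (beyond the scatter), and the new group sits level with the pyrazin-2-yl group, with a number 4 percentage points lower from compound 2 to compound 4 (within the scatter). Compound 1 and compound 4 share a pyridin-2-yl ring yet show a number 30 percentage points lower from compound 1 to compound 4 (beyond the scatter), so at this place the ring alone does not set the percentage remaining, and what it carries counts as well. Nothing shown accounts for any of these steps.

The compounds shown cannot separate the contribution of the nitrile from that of the pyridin-2-yl ring holding it, and an unsubstituted pyridin-2-yl group, or a primary amide where the nitrile stands, would bear on that. On these data alone, it also stays open whether the number of compound 3 belongs to the pyridazin-3-yl group alone, which a pyridazin-3-yl ring carrying a nitrile or a methoxy group would test.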